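Cyclopropyl for Propyl on the Amide Nitrogen Chain

The compounds below may be only part of what the source reports. "The series", "measured", "known", "first", "only" and "open" are said of these compounds alone.

Compound 1: `CCCN(C(=O)c1ccccc1OCc1ccccc1)[C@@H]1CCC[C@H](N)C1`, 1430 nM
Compound 2: `CCCCN(C(=O)c1ccccc1OCc1ccccc1)[C@@H]1CCC[C@H](N)C1`, 1560 nM

In an assay on HEK293 cells for inhibition of transient receptor potential cation channel subfamily M member 8 (Homo sapiens), read by FLIPR and calcium flux (on this read-out higher numbers stand for weaker inhibition and lower numbers for stronger inhibition), compound 2 gives 1560 nM, the higher of the two numbers, yet the step of a 1.1-fold higher number from compound 1 to compound 2 (0.04 log units; within the scatter) lies within the scatter, so the two compounds are indistinguishable here. Compound 3 is `N[C@H]1CCC[C@@H](N(CC2CC2)C(=O)c2ccccc2OCc2ccccc2)C1`, differing from compound 2 by cyclopropyl in place of propyl on a saturated chain carbon bound to an amide-type nitrogen. Among the measured compounds shown here, the one measured step, a 1.1-fold higher number from compound 1 to compound 2 (0.04 log units; within the scatter), lengthened the same chain by a methyl without effect; closing three chain carbons into a ring has no measured counterpart here. Compound 3 is therefore expected to show no step beyond the scatter, a 1.0-fold lower number from compound 2 to compound 3 (0.02 log units; within the scatter). Compound 3 is estimated at 1500 nM, within 500 nM to 4500 nM.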

Compound 3, antagonist equilibrium constant: 665 nM
Compound 3: middle estimate off by 2.3-fold (0.35 log units), on the high side; the range from low to high includes it.
By their numbers in this assay, from the lowest: compound 3; then compounds 1 and 2 (each within the scatter of the next).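

In this assay, lengthening the chain on the saturated carbon bound to an amide-type nitrogen changed nothing measurable, but a ring there does matter: cyclopropyl in place of propyl gives a 2.3-fold lower number from compound 2 to compound 3 (0.37 log units; beyond the scatter), and cyclopropyl in place of ethyl gives a 2.2-fold lower number from compound 1 to compound 3 (0.33 log units; beyond the scatter). Both steps are modest, yet compound 3 stands apart from both open-chain compounds, although the group that enters has the same number of heavy atoms as the propyl that leaves. Nothing available explains this stronger inhibition. Among the compounds shown here, whether larger rings such as cyclobutyl or cyclopentyl would go further at this place remains open, and compound 3 is the only ring example here.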